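Solubility of a third piperidine variant in the shared core

This account rests on a few compounds, and the source may have more. Where it says the series, first, only, none or still open, it means among the compounds named here.

Of the compounds shown here, two of one shared core have been measured in a physicochemical assay for solubility, in simulated intestinal fluid, measured as thermodynamic solubility, at pH 6.8; on this read-out lower numbers stand for lower solubility and higher numbers for higher solubility. Compound 1, `CN(c1nc2c(c(Nc3ccc(C(F)(F)F)cc3)n1)CCN(c1ncccc1C(F)(F)F)CC2)C1CCCNC1`, gives 211 ug/mL. Compound 2, `CN1CCCCC1CNc1nc2c(c(Nc3ccc(C(F)(F)F)cc3)n1)CCN(c1ncccc1C(F)(F)F)CC2`, gives 254 ug/mL. Among the measured compounds shown here, the one step between them, a 1.2-fold higher number from compound 1 to compound 2 (0.08 log units; within the scatter), lies within the scatter, so the two numbers cannot be told apart. Compound 2 stands highest of the two numbers, with compound 1 nearest at a gap that is within the scatter.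

Compound 3, `FC(F)(F)c1ccc(Nc2nc(NC3CCCNC3)nc3c2CCN(c2ncccc2C(F)(F)F)CC3)cc1`, has not yet been measured. It differs from compound 2 by piperidin-3-yl in place of (1-methylpiperidin-2-yl)methyl on a nitrogen on an aromatic ring. Compound 3 thereby carries a piperidin-3-yl group on the nitrogen, as compound 1 does, but without the methyl that compound 1 carries on that same nitrogen. For the measured compounds named here, the only measured step that touches this part of the molecule is a 1.2-fold higher number from compound 1 to compound 2 (0.08 log units; within the scatter), and it was within the scatter. On that basis the expected step is a 1.1-fold lower number from compound 2 to compound 3 (0.04 log units; within the scatter), which means no change beyond the scatter in this assay. Compound 3 is therefore estimated at 230 ug/mL, with a range from 120 ug/mL to 450 ug/mL.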

Compound 3, solubility: 203 ug/mL
For compound 3 the middle estimate is 1.1-fold (0.05 log units) above the measured one; measured number inside the range.
By their numbers in this assay, from the lowest: compounds 3, 1 and 2 (each within the scatter of the next).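

In this assay, exchanging (1-methylpiperidin-2-yl)methyl for piperidin-3-yl on the nitrogen on an aromatic ring gives a 1.3-fold lower number from compound 2 to compound 3 (0.10 log units; within the scatter), so this change of side chain, which also brings one more hydrogen-bond donor, cannot be told apart from no change at all. Among the compounds shown here, the smaller edit, hydrogen in place of methyl on that same nitrogen with the piperidin-3-yl kept, gives a 1.0-fold lower number from compound 1 to compound 3 (0.02 log units; within the scatter), and this is the first view of that methyl on its own, with no difference that can be read. All three steps at this position now lie within the scatter, so the three side chains do not separate in this assay, and nothing is available that would explain this result.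

Going by these compounds, all three compounds carry a six-membered non-aromatic ring with one hetero atom at this position, so it remains open what an open-chain amine, a morpholine ring or a carboxylic acid would do there. The rest of the shared core, including both trifluoromethyl groups, is the same throughout, so these compounds say nothing about its part in the read-out.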